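The source may report more compounds than this note shows. Statements on the series, on what has been measured and on what is new or still open speak of the compounds shown alone.

Of the compounds shown here, three have been measured in an ADME assay on L929 cells (Mus musculus) for cytotoxicity, read by CCK-8 assay, with a stated time of 48 h, tested at 100 uM; a lower number here means a stronger effect, a higher number a weaker effect of the compound at the concentration tested. Compound 1 `COc1ccc(S(=O)(=O)N2CCN(c3ccccc3F)CC2)cc1S(=O)(=O)N1CCN(c2ccccc2F)CC1` gives 66.7%, compound 2 `CCOc1ccc(S(=O)(=O)N2CCN(Cc3ccccc3)CC2)cc1S(=O)(=O)N1CCN(Cc2ccccc2)CC1` gives 22.2%, and compound 3 `CCOc1ccc(S(=O)(=O)N2CCN(c3ccccc3F)CC2)cc1S(=O)(=O)N1CCN(c2ccccc2F)CC1` gives 3.7%. Compound 3 and compound 1 differ in a single place, (hydrogen in place of methyl on a saturated chain carbon bound to an oxygen on an aromatic ring), and this step is a number 63 percentage points higher from compound 3 to compound 1 (beyond the scatter). The difference between the core of compound 2 and the core of compound 3 is not broken down here; of the two, compound 3 gives the lower number, beyond the usual scatter. Compound 4 `COc1ccc(S(=O)(=O)N2CCN(Cc3ccccc3)CC2)cc1S(=O)(=O)N1CCN(Cc2ccccc2)CC1` has not yet been measured; it stands to compound 2 as compound 1 stands to compound 3, the change being (hydrogen in place of methyl on a saturated chain carbon bound to an oxygen on an aromatic ring), the same change at the same place. From compound 2 to compound 4 in this assay a step in the same direction is expected, estimated as a number 39.8 percentage points higher from compound 2 to compound 4 (beyond the scatter), somewhat smaller than the earlier one because a number 63 percentage points higher from compound 3 to compound 1 (beyond the scatter) is a single observation made on a different core, and a percentage read-out of this kind cannot rise without bound. For compound 4 the estimate is 62%, with a range from 22% to 98%.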

Compound 4, a percentage reported as activity, at one concentration (the size of the read-out at that concentration, not a potency): 22.2%
Estimate against measurement, compound 4: 39.8 percentage points above; low and high end bracket the measured number.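

In this assay, the change from ethoxy to methoxy on the core of compound 2 gives no change at the digits printed from compound 2 to compound 4 (within the scatter). Set beside the same change on the core of compound 3, the size of the step does not carry over from one core to the other: the same change on two cores in this assay, a number 63 percentage points higher (beyond the scatter) from compound 3 to compound 1 and no change at the digits printed (within the scatter) from compound 2 to compound 4, 63 percentage points apart, beyond the scatter of two such steps. This shows that, for these two pairs, the step seen on one core could not be taken as a guide to the step on the other, but it does not show which difference between the cores goes with the gap, and two steps say nothing about how the change would read on a third core.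

The compounds shown leave open what a longer chain such as propoxy, or a hydroxyl group, would give at this place on either core. They also leave open whether other cores in the series would follow compound 1 and compound 3 or compound 2 and compound 4.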